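The source may hold more compounds than are shown below. What is called first, only, known or untested is meant among the compounds shown, and "the series" means these compounds.

Compound 1, `CCCC(=O)N1CC2CC(C1)N2`, reaches 120% in an assay on SH-EP1 cells for agonist activity at Neuronal acetylcholine receptor; alpha4/beta2 (Homo sapiens), read by FLIPR and calcium flux; a higher number here means a larger maximal response, a lower number a smaller maximal response. Compound 2, `O=C([C@@H]1C[C@@H]1F)N1CC2CC(C1)N2`, reaches 120% in this assay, so the step of no change at the digits printed from compound 1 to compound 2 (within the scatter) stays within the scatter, and compound 2 stands level with compound 1. Compound 3, `C[C@H]1C[C@H]1C(=O)N1CC2CC(C1)N2`, differs from compound 2 in one place: methyl in place of fluoro on a saturated ring carbon, read one bond further out as 2-fluorocyclopropyl to 2-methylcyclopropyl. Going by the values given here, the only measured step, no change at the digits printed from compound 1 to compound 2 (within the scatter), changed the carbonyl substituent without moving the maximal response. The account therefore expects compound 3 to show no step beyond the scatter, a number 2 percentage points lower from compound 2 to compound 3 (within the scatter). The estimate for compound 3 in this assay is 118%, expected between 100% and 135%.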

Compound 3, largest response reached (Emax), in percent of the reference or control that the assay uses: 87%
Compound 3: the middle estimate sits 31 percentage points above what was measured, and the stated range ends above it.
By their numbers in this assay, from the lowest: compound 3; then compounds 1 and 2 (each within the scatter of the next).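

Going by these compounds alone, on this saturated ring carbon in this assay, the exchange of a single heavy atom matters: methyl in place of fluoro gives a number 33 percentage points lower from compound 2 to compound 3 (beyond the scatter) and is the first step here beyond the scatter. 2-methylcyclopropyl in place of propyl likewise gives a number 33 percentage points lower from compound 1 to compound 3 (beyond the scatter) and so does not match the level shared by the propyl and 2-fluorocyclopropyl groups. Nothing available explains why this exchange lowers the maximal response.

As far as these compounds go, whether a hydroxyl, an amine or a longer chain on this ring carbon would keep the maximal response or lower it remains open.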